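Amide variation on the core of compound 1

This account rests on a few compounds, and the source may have more. Where it says the series, first, only, none or still open, it means among the compounds named here.

Compound 1 `NC(=O)c1ccc(C#Cc2ccccc2)nc1`: 6600 nM
Compound 2 `O=C(NC1CCCCC1)c1ccc(C#Cc2ccccc2)nc1`: 240 nM
Compound 3 `CN1CCN(C(=O)c2ccc(C#Cc3ccccc3)nc2)CC1`: 1600 nM

Of the compounds shown here, three sharing one core have been measured in a functional assay on BHK cells for positive allosteric modulation of metabotropic glutamate receptor 5 (Homo sapiens), read by FLIPR and calcium flux; on this read-out higher numbers stand for an effect only at larger amounts of compound and lower numbers for an effect already at smaller amounts. Compound 1 carries the unsubstituted amide and stands at the highest number of the three; the nearest step away from it is a 4.1-fold lower number from compound 1 to compound 3 (0.62 log units; beyond the scatter), and the furthest is a 28-fold lower number from compound 1 to compound 2 (1.44 log units; beyond the scatter). Between the two substituted amides the step is a 6.7-fold higher number from compound 2 to compound 3 (0.82 log units; beyond the scatter), so the cyclohexylamino compound sits well below the 4-methylpiperazin-1-yl compound.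

Compound 4 `O=C(c1ccc(C#Cc2ccccc2)nc1)N1CCSCC1` has not been measured. It differs from compound 1 as follows: thiomorpholin-4-yl in place of amino on a carbonyl carbon. Among the compounds with values here, two measured steps bear on this change. Both replace the amino group on the carbonyl carbon by a larger group, and both lower the number beyond the scatter, one modestly and one by a large margin. Compound 4 replaces amino with a six-membered ring bearing two hetero atoms, closest in kind to the change in compound 3, so a modest lowering is expected, and the expected step is a 7.3-fold lower number from compound 1 to compound 4 (0.87 log units; beyond the scatter). Compound 4 is therefore estimated at 900 nM, with a range from 250 nM to 3000 nM.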

Compound 4, half-maximal effective concentration: 46 nM
Compound 4: the middle estimate sits 20-fold (1.29 log units) above what was measured, and the stated range ends above it.
By their numbers in this assay, from the lowest: compound 4; then compound 2; then compound 3; then compound 1.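

In this assay the thiomorpholin-4-yl group takes the series past both earlier substituted amides (with a 5.2-fold lower number from compound 2 to compound 4 (0.72 log units; beyond the scatter) and a 35-fold lower number from compound 3 to compound 4 (1.54 log units; beyond the scatter)) and so gives the lowest number of the four, with all of its steps beyond the scatter. Within the data shown here, the change on this carbonyl carbon can therefore reach much further than the earlier compounds showed (here a 140-fold lower number from compound 1 to compound 4 (2.16 log units; beyond the scatter)), and the large gap between the thiomorpholin-4-yl and 4-methylpiperazin-1-yl groups shows that a ring joined to the carbonyl carbon through its nitrogen does not by itself settle the number. Nothing measured here gives a reason for the size of these steps.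

Still open, as far as these compounds go, is how a morpholin-4-yl or a piperidin-1-yl group, with an oxygen or a ring carbon in the place of the sulfur, would stand on the same carbonyl carbon, which leaves the share of the sulfur in this step unknown. Also open, from the compounds shown here alone, is whether a thiomorpholine sulfone, with two oxygens on that sulfur, would hold the number of compound 4 or lose it.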